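The compounds below may be only part of what the source reports. "The series", "measured", "known", "first", "only" and "open" are said of these compounds alone.

Measured in a functional assay on the whole organism (strain Wistar) for inhibition, with Rattus norvegicus as the target, read by paw edema, with stated times of 60 min and 2 h, at a dose of 100 mg/kg by the oral route; a higher number here means more inhibition at the dose given (going by the name of the read-out), a lower number less inhibition:
compound 1 `COc1cc2c(cc1OC)C(CC(=O)N(C)C)CC2` gives 36%
compound 2 `CCCNC(=O)CC1CCc2cc(OC)c(OC)cc21` gives 28%
compound 3 `CCCCCNC(=O)CC1CCc2cc(OC)c(OC)cc21` gives 34%

The number for compound 2 is the smallest of the three, yet the separations a number 8 percentage points lower from compound 1 to compound 2 (within the scatter) and a number 6 percentage points higher from compound 2 to compound 3 (within the scatter) both lie within the scatter, so the three compounds are not told apart by these data. Compound 4 `COc1cc2c(cc1OC)C(CC(=O)N1CCNCC1)CC2` differs from compound 2 by piperazin-1-yl in place of propylamino on a carbonyl carbon. The measured steps that bear on this change are the two other replacements on the same carbonyl carbon, a number 8 percentage points lower from compound 1 to compound 2 (within the scatter) and a number 2 percentage points lower from compound 1 to compound 3 (within the scatter), both within the scatter, so no step beyond the scatter is expected in this assay here either. Compound 4 is therefore expected to give 32%, within 18% to 46%, a step of a number 4 percentage points higher from compound 2 to compound 4 (within the scatter) that is expected to stay inside the scatter.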

Compound 4, a percentage reported as inhibition, in the whole organism at one dose (the size of the read-out at that dose, not a potency): 44%
Compound 4: the middle estimate sits 12 percentage points below what was measured; measured number inside the range.
By their numbers in this assay, from the lowest: compounds 2, 3, 1 and 4 (each within the scatter of the next, the first and the last beyond it).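

Piperazin-1-yl in place of propylamino on a carbonyl carbon gives a number 16 percentage points higher from compound 2 to compound 4 (beyond the scatter) in this assay and is the first step at this position to pass the scatter. The same group set against pentylamino gives a number 10 percentage points higher from compound 3 to compound 4 (within the scatter) and set against dimethylamino gives a number 8 percentage points higher from compound 1 to compound 4 (within the scatter) and both stay within the scatter, so compound 4 is set apart from compound 2 alone. From the compounds shown here alone, whether morpholin-4-yl or 4-methylpiperazin-1-yl would match piperazin-1-yl here remains open. Nothing available explains the step from propylamino to piperazin-1-yl.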